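The source may hold more compounds than are shown below. What is called first, only, known or untested is meant among the compounds shown, and "the series" means these compounds.

Measured so far in a functional assay on HCT-116 cells (Homo sapiens) for inhibition, read by MTT assay, with a stated time of 48 h; on this read-out lower numbers stand for stronger inhibition and higher numbers for weaker inhibition:
compound 1 `COc1ccc(CN(C(=O)C(C)Br)c2cc(OC)c(OC)c(OC)c2)cc1O` gives 140 nM
compound 2 `CCC(=O)N(Cc1ccc(OC)c(O)c1)c1cc(OC)c(OC)c(OC)c1` gives 61 nM
compound 3 `COc1ccc(CN(C(=O)CN=[N+]=[N-])c2cc(OC)c(OC)c(OC)c2)cc1O` gives 410 nM

Compound 3 stands highest of the three numbers; the nearest is compound 1 (a 2.9-fold higher number from compound 1 to compound 3 (0.47 log units; beyond the scatter)), the furthest compound 2 (a 6.7-fold higher number from compound 2 to compound 3 (0.83 log units; beyond the scatter)). Compound 4 `COc1ccc(CN(C(=O)CBr)c2cc(OC)c(OC)c(OC)c2)cc1O` differs from compound 3 by bromo in place of azido on a saturated chain carbon bound to a carbonyl carbon. The step of a 6.7-fold higher number from compound 2 to compound 3 (0.83 log units; beyond the scatter) shows the azido group raising the number by the larger margin, while a 2.3-fold lower number from compound 1 to compound 2 (0.36 log units; beyond the scatter) shows bromo costing only a modest amount against hydrogen. Removing azido for bromo is therefore expected to lower the number beyond the scatter, by roughly a 3.2-fold lower number from compound 3 to compound 4 (0.50 log units; beyond the scatter). Compound 4 is estimated at 130 nM, within 50 nM to 350 nM.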

Compound 4, half-maximal inhibitory concentration: 68 nM
Compound 4: middle estimate off by 1.9-fold (0.28 log units), on the high side; measured number inside the range.
By their numbers in this assay, from the lowest: compounds 2 and 4 (each within the scatter of the next); then compound 1; then compound 3.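

On the saturated chain carbon bound to a carbonyl carbon, the azido group, not the presence of a substituent there, goes with the high number: swapping it for bromo recovers most of the loss (a 6.0-fold lower number from compound 3 to compound 4 (0.78 log units; beyond the scatter)). Bromo and methyl at this place read alike (a 1.1-fold higher number from compound 2 to compound 4 (0.05 log units; within the scatter)), whereas adding a methyl to the bromine-bearing carbon carries a modest cost, seen in reverse (a 2.1-fold lower number from compound 1 to compound 4 (0.31 log units; beyond the scatter)). No measurement here gives a reason for these differences.

Open, on these data alone, is whether an amine or a carboxylic acid on this carbon reads like bromo and methyl or like azido. Also open, as far as these compounds go, is whether a longer chain keeps the number this low.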